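A few compounds are considered here, and "the series" means these few. Any claim that something is new, unique, unknown or untested is made for them only; others in the source may bear on it.

Compound 2 `CC(C)(C)c1ccc(NC(=O)c2ccc(-c3ccccn3)cc2)cc1` is the starting point here. Within the data shown here, in a functional assay for antagonist activity at transient receptor potential cation channel subfamily V member 1 (Homo sapiens), read by FLIPR (a lower number here means a stronger inhibitor, a higher number a weaker inhibitor), compound 2 gives 11 nM, level with compound 1 `Cc1cccnc1-c1ccc(C(=O)Nc2ccc(C(C)(C)C)cc2)cc1`, which gives 11 nM; together these two are the lowest of the three numbers known, and the step of no change at the digits printed from compound 1 to compound 2 (within the scatter) lies within the scatter. Compound 3 `CN(C)Cc1cccnc1-c1ccc(C(=O)Nc2ccc(C(C)(C)C)cc2)cc1` gives 746 nM, so the step of a 68-fold higher number from compound 2 to compound 3 (1.83 log units; beyond the scatter) is large and well beyond the scatter.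

Compound 4 `CC(C)(C)c1ccc(NC(=O)c2ccc(-c3ncccc3-c3ncc[nH]3)cc2)cc1` differs from compound 2 by 1H-imidazol-2-yl in place of hydrogen on an aromatic carbon. Among the measured compounds shown here, two measured steps concern this same position on the six-membered aromatic ring with 1 nitrogen: no change at the digits printed from compound 1 to compound 2 (within the scatter) shows that a methyl there makes no difference, whereas a 68-fold higher number from compound 2 to compound 3 (1.83 log units; beyond the scatter) shows that a (dimethylamino)methyl there weakens inhibition a great deal. The 1H-imidazol-2-yl group is neither of those, so a loss of intermediate size is expected, with the number rising. Compound 4 is therefore estimated at 120 nM, with a range from 20 nM to 900 nM, which would mean an expected step of an 11-fold higher number from compound 2 to compound 4 (1.04 log units; beyond the scatter).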

Compound 4, half-maximal inhibitory concentration: 3670 nM
Compound 4: the middle estimate sits 31-fold (1.49 log units) below what was measured, outside the stated range (above it).
By their numbers in this assay, from the lowest: compounds 1 and 2 (each within the scatter of the next); then compound 3; then compound 4.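

A methyl at this place on the six-membered aromatic ring with 1 nitrogen changes nothing, yet the position does not accept every group: in this assay, 1H-imidazol-2-yl brings a large loss whether it replaces hydrogen (a 330-fold higher number from compound 2 to compound 4 (2.52 log units; beyond the scatter)) or methyl (a 330-fold higher number from compound 1 to compound 4 (2.52 log units; beyond the scatter)). It also goes a modest step beyond the (dimethylamino)methyl group (a 4.9-fold higher number from compound 3 to compound 4 (0.69 log units; beyond the scatter)), so the highest number at this place now belongs to an aromatic ring rather than to a chain carrying an amine. No measurement here accounts for these losses.

Going by these compounds, whether the loss belongs to the ring itself or to its hydrogen on nitrogen stays open, and a 1-methylimidazol-2-yl or a furan-2-yl group in the same place would separate the two. An ethyl or a methoxy group would show how soon the number begins to climb once the group grows beyond methyl.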